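The source may hold more compounds than are shown below. What is called first, only, known or untested is meant among the compounds shown, and "the series" means these compounds.

Measured values in a functional assay on A-431 cells (Homo sapiens) for cytotoxicity, read by MTT assay, with a stated time of 72 h; on this read-out lower numbers stand for stronger inhibition and higher numbers for weaker inhibition:

compound 1 `Cc1ccnc(/C(N)=N/NC(=S)N2CCSCC2)c1`: 7200 nM
compound 2 `Cc1ccnc(/C(N)=N/NC(=S)N2CCCCCC2)c1`: 8000 nM
compound 3 `N/C(=N\NC(=S)N1CCN(c2ccccn2)CC1)c1ccc(F)cn1`: 13400 nM

Compound 1 has the lowest of the three numbers in this assay. Compound 2 sits closest to it, and compound 3 is the furthest away; both gaps fall within the scatter, so no order among the three compounds can be read from these values. Compounds 1 and 2 share the same core and differ only in the group on the thiocarbonyl carbon, while compound 3 carries a different substitution pattern on its core and a different group on the thiocarbonyl carbon.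

Compound 4 `Cc1ccnc(/C(N)=N/NC(=S)N2CCOCC2)c1` has not yet been measured in this assay. It differs from compound 1 in one place: morpholin-4-yl in place of thiomorpholin-4-yl on a thiocarbonyl carbon. Among the compounds with values here, no measured pair shows a step of this kind, so the size of the change can only be guessed from how little the three measured values spread. A step of no size beyond the scatter, in either direction, is expected for compound 4, with the step of a 1.3-fold higher number from compound 1 to compound 4 (0.10 log units; within the scatter) as the estimate. Compound 4 is therefore expected to give 9000 nM in this assay, within a range from 4000 nM to 20000 nM.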

Compound 4, half-maximal inhibitory concentration: 6800 nM
Compound 4: the middle estimate sits 1.3-fold (0.12 log units) above what was measured; the range from low to high includes it.
By their numbers in this assay, from the lowest: compounds 4, 1, 2 and 3 (each within the scatter of the next).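

Within the data shown here, this is the only pair that differs in one place. In this assay, morpholin-4-yl in place of thiomorpholin-4-yl on a thiocarbonyl carbon gives a 1.1-fold lower number from compound 1 to compound 4 (0.02 log units; within the scatter), so exchanging sulfur for oxygen in this six-membered ring produces no readable difference on the shared core. Nothing available accounts for this result.

From the compounds shown here alone, whether the same holds for an unsubstituted piperazine or an open-chain dimethylamino group on the thiocarbonyl carbon remains open. Also open, going by these compounds, is whether the exchange of sulfur for oxygen would read the same on a core carrying fluorine in place of the methyl group.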